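The source may hold more compounds than are shown below. What is called first, only, known or untested is meant among the compounds shown, and "the series" means these compounds.

Working notes on the series.

Compound 1 `N=c1sc(=S)[nH]c2c1cc(-c1ccccc1)n2-c1ccccc1` gives 0% in a functional assay on the whole organism for inhibition, with Rattus norvegicus as the target, read by ELISA, with stated times of 30 min and 6 h, at a dose of 30 mg/kg by the oral route; a higher number here means more inhibition at the dose given (going by the name of the read-out), a lower number less inhibition. Going by the values given here, compound 2 `N=c1sc(=S)[nH]c2c1cc(-c1ccc(Cl)cc1)n2-c1ccccc1` gives 2%; the step of a number 2 percentage points higher from compound 1 to compound 2 (within the scatter) is the only measured step that carries this structural change, and it does not leave the scatter. Compound 3 `CCSc1nc2c(cc(-c3ccccc3)n2-c2ccccc2)c(=N)s1` gives 0%, level with compound 1 at the digits shown; the values of compound 3 and compound 2 lie within the scatter of each other, so no order can be read among the three measured compounds.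

Compound 4 `CCSc1nc2c(cc(-c3ccc(Cl)cc3)n2-c2ccccc2)c(=N)s1` differs from compound 3 by chloro in place of hydrogen on an aromatic carbon. Among the compounds with values here, the one step that bears on this change, a number 2 percentage points higher from compound 1 to compound 2 (within the scatter), was flat, so no shift beyond the scatter is expected in this assay in either direction. On that basis the estimate for compound 4 is 0%, with a range from 0% to 10%. Within the data shown here, the step this implies, no change at the digits printed from compound 3 to compound 4 (within the scatter), is expected to stay within the scatter, because compound 3 gives 0% and the only comparable step a number 2 percentage points higher from compound 1 to compound 2 (within the scatter) did not move.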

Compound 4, a percentage reported as inhibition, in the whole organism at one dose (the size of the read-out at that dose, not a potency): 1%
The estimate for compound 4 lay 1 percentage points below the measured number; the range from low to high includes it.
By their numbers in this assay, from the lowest: compounds 1, 3, 4 and 2 (each within the scatter of the next).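

In this assay, the change from phenyl to 4-chlorophenyl, with chloro on an aromatic carbon para to a large group, now has a reading on a second core: the step is a number 1 percentage points higher from compound 3 to compound 4 (within the scatter). The flat result for this change no longer rests on a single pair, and the two cores agree: the same change on two cores in this assay, a number 2 percentage points higher (within the scatter) from compound 1 to compound 2 and a number 1 percentage points higher (within the scatter) from compound 3 to compound 4, 1 percentage points apart, within the scatter of two such steps. This agreement comes only from compounds showing almost no inhibition at this dose, so it says nothing about how chloro behaves on a compound with clear inhibition.

On these data alone, it remains open whether another group at this position, such as methoxy, an amine or a carboxylic acid, would give a step beyond the scatter. As far as these compounds go, it also remains open whether a longer chain in place of the ethyl group of compound 3 would do so.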